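A methoxy group moves from compound 1 to compound 3

The compounds below may be only part of what the source reports. "The series", "measured", "known", "first", "only" and "open" are said of these compounds alone.

Among the measured compounds shown here, compound 1 `COc1ccc(OCC(O)CN2CCC(N3Cc4ccccc4C3=O)CC2)cc1` holds the only numerical value in an assay on isolated protein for inhibition of sodium channel protein type 1 subunit alpha (Homo sapiens), read by patch clamp (on this read-out higher numbers stand for weaker inhibition and lower numbers for stronger inhibition), where compound 1 gives 2700 nM. Compound 2 `O=C(c1ccccc1)c1ccccc1OCC(O)CN1CCN(c2cccc3[nH]c(=O)oc23)CC1` gives > 33000 nM in this assay, which is a limit of the assay rather than a number, namely (the limit of > 33000 nM in this assay, at which 1 of the 2 values shown sits). Compound 3 `COc1cccc(OCC(O)CN2CCC(N3Cc4ccccc4C3=O)CC2)c1` differs from compound 1 by 3-methoxyphenyl in place of 4-methoxyphenyl on an oxygen on a saturated carbon. For the measured compounds named here, no measured pair shows such a change. The step of a 1.3-fold higher number from compound 1 to compound 3 (0.11 log units; within the scatter) is therefore expected to stay within the usual scatter, with no clear direction. Compound 3 is estimated to give 3500 nM in this assay, with a likely range from 1200 nM to 12000 nM.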

Compound 3, half-maximal inhibitory concentration: 3000 nM
For compound 3 the middle estimate is 1.2-fold (0.07 log units) above the measured one, within the range that was stated.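

In this assay, among the compounds shown here, 3-methoxyphenyl in place of 4-methoxyphenyl on this oxygen gives a 1.1-fold higher number from compound 1 to compound 3 (0.05 log units; within the scatter) and so gives the first measured reading of this change. At this place, the two methoxy positions cannot be told apart in this assay. Nothing shown accounts for this result.

The compounds shown leave open whether an amine or a carboxylic acid in place of the methoxy group would move the value beyond the scatter. They also leave open what a longer chain on this oxygen would do.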